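Indole in place of methoxyphenyl: an untested step

The source may report more compounds than this note shows. Statements on the series, on what has been measured and on what is new or still open speak of the compounds shown alone.

Measured so far:
compound 1 `CCC(C)[C@H](N)c1cc(C(F)(F)F)ccc1N1CCN(C(=O)CCc2ccc(OC)c(OC)c2Cl)CC1`: 2500 nM
compound 2 `COc1cccc(CCC(=O)N2CCN(c3ccc(C(F)(F)F)cc3[C@@H](N)CC(C)C)CC2)c1`: 4000 nM

Both compounds were tested in an assay on HEK293 cells for displacement of a labelled ligand from Melanocortin receptor 4 (Homo sapiens); on this read-out higher numbers stand for weaker inhibition and lower numbers for stronger inhibition. Compound 1 gives 2500 nM, and compound 2 gives 4000 nM; these two numbers lie within the usual scatter of each other, so neither stands apart. Compound 3 `Cc1[nH]c2ccccc2c1CCC(=O)N1CCN(c2ccc(C(F)(F)F)cc2[C@@H](N)CC(C)C)CC1` has not yet been measured. It differs from compound 2 in one place: 2-methyl-1H-indol-3-yl in place of 3-methoxyphenyl on a saturated chain carbon, two bonds along the chain from a carbonyl carbon. For the measured compounds named here, no measured pair shows this change, so its effect is unknown. The expected step is a 2.7-fold lower number from compound 2 to compound 3 (0.43 log units; beyond the scatter), toward a lower number, though it may not exceed the scatter. Compound 3 is therefore estimated at 1500 nM, within 400 nM to 6000 nM.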

Compound 3, inhibition constant: 1600 nM
Estimate against measurement, compound 3: 1.1-fold (0.03 log units) below; low and high end bracket the measured number.
By their numbers in this assay, from the lowest: compounds 3, 1 and 2 (each within the scatter of the next, the first and the last beyond it).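

At this position, on a saturated chain carbon two bonds along the chain from a carbonyl carbon, 2-methyl-1H-indol-3-yl in place of 3-methoxyphenyl gives a 2.5-fold lower number from compound 2 to compound 3 (0.40 log units; beyond the scatter) in this assay and this modest step lies beyond the scatter. The position therefore tolerates a group with more heavy atoms and a second aromatic ring, and one hydrogen-bond donor in place of one acceptor, with no loss of inhibition. Nothing shown explains the gain.

From the compounds shown here alone, it remains open whether the methyl group contributes, which plain 1H-indol-3-yl would test. A longer chain to the indole is also an open comparison.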